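The source may report more compounds than this note shows. Statements on the series, on what has been measured and on what is new or still open speak of the compounds shown alone.

Working notes on the series. In an ADME assay on CHO cells (Cricetulus griseus) for cytotoxicity, read by MTT assay (a higher number here means that more compound is tolerated, a lower number that less compound is tolerated), compound 1 (`CN1CCN(CC2CCN(c3nccc4[nH]c(-c5ccc(F)c(F)c5)nc34)CC2)CC1`) gives 7400 nM and compound 2 (`NC1CCN(c2nccc3[nH]c(-c4cccc(OC(F)(F)F)c4)nc23)CC1`) gives 42000 nM as the half-maximal cytotoxic concentration. Compound 2 holds the higher of the two numbers, and its gap to compound 1 lies beyond the usual scatter. These two compounds differ in more than one place, so the gap cannot be tied to any single change.

Compound 3 (`NCC1CCN(c2nccc3[nH]c(-c4cccc(OC(F)(F)F)c4)nc23)CC1`) differs from compound 2 in one place (aminomethyl in place of amino on a saturated ring carbon): aminomethyl in place of amino on a saturated ring carbon, or 4-aminopiperidin-1-yl to 4-(aminomethyl)piperidin-1-yl. Among the measured compounds shown here, no measured pair shows this change in this assay so far, and the expectation is therefore loose. For the measured compounds named here, compound 2 at 42000 nM is the higher of only two values, so any expected movement points towards compound 1 at 7400 nM rather than further upward. The expected change is small (a 1.5-fold lower number from compound 2 to compound 3 (0.18 log units; within the scatter)) and would stay within the scatter, downward if anything. Compound 3 is estimated at 28000 nM (range 11000 nM to 65000 nM).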

Compound 3, half-maximal cytotoxic concentration in the CHO assay: 2900 nM
Compound 3: the middle estimate sits 9.7-fold (0.98 log units) above what was measured; the whole stated range lies above it.
By their numbers in the CHO assay, from the lowest: compound 3; then compound 1; then compound 2.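

Among the compounds shown here, in the CHO assay, compound 2 gives 42000 nM and compound 3 gives 2900 nM; aminomethyl in place of amino on a saturated ring carbon, three ring bonds from the ring nitrogen, gives a 14-fold lower number from compound 2 to compound 3 (1.16 log units; beyond the scatter), the first step that can be tied to one place, and it shows that tolerance in this assay is sensitive to what this position carries. The same change leaves a physicochemical assay for solubility, read by HPLC, using the shake flask method, in phosphate buffer, with a stated time of 20 h, at pH 6.5 (a higher number here means a more soluble compound, a lower number a less soluble compound), flat, where compound 2 gives 200000 nM and compound 3 gives 200000 nM, showing no change at the digits printed from compound 2 to compound 3 (within the scatter), so within this pair the two assays part ways at this position. Amino and aminomethyl have the same counts of hydrogen-bond donors and acceptors and no net charge, and nothing on hand accounts for the step.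

For the compounds shown here, with only this pair, it stays open whether the tolerated concentration keeps moving the same way with a longer chain such as aminoethyl, or whether a hydroxyl or a dimethylamino group on the same ring carbon would give a similar step. From the compounds shown here alone, it is also open whether the step carries over to the aryl group of compound 1, which differs from compound 2 in more than one place.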